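The source may hold more compounds than are shown below. What is called first, only, known or untested is meant among the compounds shown, and "the series" means these compounds.

Compound 1, `CN(C)C(=O)c1cc2cnc(Nc3ccc(NC(=O)C4(C(=O)Nc5ccc(F)cc5)CC4)cc3)nc2n1C1CCCC1`: 86.6%
Compound 2, `Nc1ccc(NC(=O)C2(C(=O)Nc3ccc(F)cc3)CC2)cc1F`: 16.3%
Compound 3, `CN(C)C(=O)c1cc2cnc(Nc3ccc(NC(=O)C4(C(=O)Nc5ccc(Cl)c(C(F)(F)F)c5)CC4)cc3)nc2n1C1CCCC1`: 1.1%

All three were measured in a functional assay on A549 cells (Homo sapiens) for inhibition, read by CCK-8 assay, with a stated time of 72 h, tested at 1 uM; a higher number here means more inhibition of growth at the concentration tested, a lower number less inhibition of growth. Compound 3 stands lowest of the three numbers, beyond the scatter below both of the others: compound 2 is the nearer of the two, and compound 1, which shares the same core and the same cyclopropane diamide with compound 3, is the furthest away, with the highest number of the set.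

Going by the values given here, compound 4, `CN(C)C(=O)c1cc2cnc(Nc3ccc(NC(=O)C4(C(=O)Nc5ccccc5)CC4)cc3)nc2n1C1CCCC1`, is not yet measured. phenyl in place of 4-chloro-3-(trifluoromethyl)phenyl on an amide-type nitrogen The change sits at the same amide-type nitrogen where the only measured step with a bearing on it occurred: a number 85.5 percentage points lower from compound 1 to compound 3 (beyond the scatter). That step shows how strongly this assay responds when the group on that nitrogen is exchanged. Compound 4 carries plain phenyl there, a group that by its count of atoms lies much closer to the 4-fluorophenyl of compound 1 than to the 4-chloro-3-(trifluoromethyl)phenyl of compound 3. Going back in that direction is therefore expected to recover most of what was lost, a large upward step of a number 70.9 percentage points higher from compound 3 to compound 4 (beyond the scatter). Compound 4 is estimated to give 72%, with a range from 40% to 92%.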

Compound 4, percent growth inhibition at one concentration: 75%
The estimate for compound 4 lay 3 percentage points below the measured number; the range from low to high includes it.
By their numbers in this assay, from the lowest: compound 3; then compound 2; then compound 4; then compound 1.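

In this assay, phenyl in place of 4-chloro-3-(trifluoromethyl)phenyl on the amide-type nitrogen gives a number 73.9 percentage points higher from compound 3 to compound 4 (beyond the scatter), so the plain ring already carries most of the inhibition seen in this series, and the collapse goes with the added chloro and trifluoromethyl groups rather than with the ring itself. The fluoro of the 4-fluorophenyl group counts for far less: hydrogen in its place gives a number 11.6 percentage points lower from compound 1 to compound 4 (beyond the scatter), a modest step that is still beyond the scatter, so a single fluoro adds only a little to what phenyl already gives. Nothing measured here explains why either step has the size it does.

Still open, on these data alone, is whether chloro alone or trifluoromethyl alone on the phenyl would pull the number down as far as the two together, and how a methoxy group or an amine on that ring, or a saturated ring such as cyclohexyl in place of phenyl, would read in this assay. As far as these compounds go, whether these steps would keep their size on a different core also remains open.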